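A few compounds are considered here, and "the series" means these few. Any claim that something is new, unique, unknown or untested is made for them only; others in the source may bear on it.

Measured so far in a functional assay (brain) for inhibition, with Rattus norvegicus as the target; on this read-out lower numbers stand for stronger inhibition and higher numbers for weaker inhibition:

compound 1, `Cc1c(C)c2c(c(C)c1O)CCC(C)(CC[N+](C)(C)C)O2`, gives 2600 nM
compound 2, `Cc1c(C)c2c(c(C)c1O)CC[C@](C)(CC(=O)[N-][N+](C)(C)C)O2`, gives 8000 nM
compound 3, `Cc1c(C)c2c(c(C)c1O)CCC(C)(CC(=O)[N-][N+](C)(C)C)O2`, gives 6000 nM

Compound 2 and compound 3 share every atom and bond; the only difference is how one stereocentre is drawn: the two compounds have the same atoms and bonds; at least one stereo element is drawn with a configuration in one of them and without one in the other: 1 of 1 stereo elements differ; a stereocentre at a saturated ring carbon is drawn without a configuration in compound 3 and R in compound 2. Their two numbers lie within the scatter of each other, which fits with the fact that one of compounds 2 and 3 is drawn with a defined configuration and the other without, at the place where they differ, so they are treated here as essentially the same core.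

From compound 3 to compound 1 one group is swapped for another: a group of 5 heavy atoms (4 carbon, 1 nitrogen; no ring) in place of a group of 7 heavy atoms (4 carbon, 2 nitrogen, 1 oxygen; no ring), on a saturated chain carbon bound to a saturated ring carbon. In this assay that swap gave a 2.3-fold lower number from compound 3 to compound 1 (0.36 log units; beyond the scatter), a modest change in the direction of stronger inhibition.

Compound 4, `Cc1c(C)c2c(c(C)c1O)CC[C@](C)(CC[N+](C)(C)C)O2`, has not yet been measured in this assay. It relates to compound 2 exactly as compound 1 relates to compound 3: a group of 5 heavy atoms (4 carbon, 1 nitrogen; no ring) in place of a group of 7 heavy atoms (4 carbon, 2 nitrogen, 1 oxygen; no ring), on a saturated chain carbon bound to a saturated ring carbon. The place where the group sits is described in the same words in both pairs, so this is the same change made on a core that differs only in the drawing of the stereocentre.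

Within the data shown here, with only one measured example of this change, the expectation rests on the step from compound 3 to compound 1, a 2.3-fold lower number from compound 3 to compound 1 (0.36 log units; beyond the scatter), applied to the value of compound 2, 8000 nM. The step from compound 2 to compound 4 is expected to be about a 2.3-fold lower number from compound 2 to compound 4 (0.36 log units; beyond the scatter). Compound 4 is therefore estimated to give about 3500 nM in this assay, most likely between 1800 nM and 7000 nM.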

Compound 4, half-maximal inhibitory concentration: 2200 nM
Estimate against measurement, compound 4: 1.6-fold (0.20 log units) above; the measured number falls inside the stated range.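

In this assay, the swap of the uncharged group of 7 heavy atoms for the group of 5 heavy atoms with net charge +1 gives a 3.6-fold lower number from compound 2 to compound 4 (0.56 log units; beyond the scatter), and set beside the earlier case the size of the step holds up: the same change on two cores in this assay, a 2.3-fold lower number (0.36 log units; beyond the scatter) from compound 3 to compound 1 and a 3.6-fold lower number (0.56 log units; beyond the scatter) from compound 2 to compound 4, 1.6-fold (0.20 log units) apart, within the scatter of two such steps. The two products of the swap stand at a 1.2-fold lower number from compound 1 to compound 4 (0.07 log units; within the scatter), so they count as no real difference, which fits with how they are drawn: the fact that one of compounds 1 and 4 is drawn with a defined configuration and the other without, at the place where they differ. This shows that the change carried over between these two cores in direction and size, but those cores differ only in how one stereocentre is drawn, so it does not show that the change would carry over to a core with different atoms or bonds.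

The group that enters differs from the group that leaves in size, charge and hydrogen-bond acceptors all at once, so the compounds shown leave open which of these differences goes with the lower number. Going by these compounds, a primary amine, a carboxylic acid or a longer chain on the same saturated chain carbon could help separate them, and the opposite drawn configuration at the stereocentre also remains open.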